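From pyridin-2-yl to pyridin-4-yl in compound 3

A few compounds are considered here, and "the series" means these few. Any claim that something is new, unique, unknown or untested is made for them only; others in the source may bear on it.

Compound 1 `CC(C)n1ncc2c(C(=O)N3CCc4cc(F)ccc43)cc(-c3cccs3)nc21` gives > 200000 nM (a limit, not a number)
Compound 2 `CC(C)n1ncc2c(C(=O)Nc3ccccc3F)cc(-c3ccccn3)nc21` gives 100000 nM

Of the compounds shown here, two have been measured so far in an ADME assay on LLC-MK2 cells (Macaca mulatta) for cytotoxicity, read by spectrophotometry and crystal violet staining, with a stated time of 4 days (a higher number here means that more compound is tolerated, a lower number that less compound is tolerated), and only one of them has an exact number. Compound 1 reads > 200000 nM and this is a limit of the assay, not a number. Among the measured compounds shown here, compound 2 gives 100000 nM as the only exact value in the set, so it has no measured neighbour to be compared with step by step.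

Compound 3 `CC(C)n1ncc2c(C(=O)Nc3ccccc3F)cc(-c3ccncc3)nc21` differs from compound 2 in one place, with pyridin-4-yl in place of pyridin-2-yl on an aromatic carbon and the same atoms joined differently. For the measured compounds named here, no measured pair shows what such a change does in this assay here, so no step beyond the usual scatter is expected, in either direction. This expectation rests on compound 2 at 100000 nM and on the structural change alone. The expected step of no change at the digits printed from compound 2 to compound 3 (within the scatter) is therefore small. Compound 3 is estimated at 100000 nM with an expected range from 45000 nM to 200000 nM when it is measured.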

Compound 3, half-maximal cytotoxic concentration: 45000 nM
For compound 3 the middle estimate is 2.2-fold (0.35 log units) above the measured one; the range from low to high includes it.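

Among the compounds shown here, exchanging pyridin-2-yl for pyridin-4-yl on the aromatic carbon next to the ring nitrogen gives the first step that can be read in this assay, a 2.2-fold lower number from compound 2 to compound 3 (0.35 log units; beyond the scatter), so less compound is tolerated after the change. For the compounds shown here, the two groups have the same atoms and the same counts of donors and acceptors, so a different joining of those atoms is enough to shift the number at this position, which the earlier compounds could not show. Nothing shown accounts for the step.

On these data alone, whether pyridin-3-yl, phenyl or an aminopyridine at this place would give a value near that of compound 2 or that of compound 3 remains open, as does whether the step would persist with a different group on the amide. For compound 1, > 200000 nM is a limit and not a number, and this compound differs from the other two in more than one place, so steps to it cannot be read.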